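Swapping the sulfinyl chain of compound 1 for a ketone chain

The source may report more compounds than this note shows. Statements on the series, on what has been measured and on what is new or still open speak of the compounds shown alone.

Measured compounds:
- compound 1, `CCC[S+]([O-])c1sc2nc(-c3cccs3)cc(-c3ccccc3)c2c1N`: 2.1 nM
- compound 2, `CCC[S+]([O-])c1sc2nc(-c3cccs3)cc(C(=O)O)c2c1N`: 71 nM
- compound 3, `CCC[S+]([O-])c1sc2nc(-c3cccs3)cc(C(=O)OCC)c2c1N`: 2 nM

In an assay for inhibition of 15-hydroxyprostaglandin dehydrogenase [NAD(+)] (Homo sapiens), read by fluorescence, with a stated time of 15 min, in the presence of a further agent that is not named here (a lower number here means a stronger inhibitor, a higher number a weaker inhibitor), compound 1 gives 2.1 nM, the second highest of the three numbers. Its nearest neighbour is compound 3, with a 1.1-fold lower number from compound 1 to compound 3 (0.02 log units; within the scatter); its furthest is compound 2, with a 34-fold higher number from compound 1 to compound 2 (1.53 log units; beyond the scatter). Between the last two stands a 36-fold lower number from compound 2 to compound 3 (1.55 log units; beyond the scatter). All three measured steps concern the group on the other aromatic carbon of the shared core, not the chain studied here.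

Compound 4, `CCCCC(=O)c1sc2nc(-c3cccs3)cc(-c3ccccc3)c2c1N`, differs from compound 1 in a group of 6 heavy atoms (5 carbon, 1 oxygen; no ring) in place of a group of 5 heavy atoms (3 carbon, 1 oxygen, 1 sulfur; no ring), on an aromatic carbon. Among the compounds with values here, no measured step touches this position, so the three steps seen so far give no direct guide to its size or direction. With a similar size of group at the same place, the number for compound 4 is expected to stay near that of compound 1, with the uncertainty widened on the weaker side: the estimated step is a 2.4-fold higher number from compound 1 to compound 4 (0.38 log units; beyond the scatter). Compound 4 is therefore estimated at 5 nM, within a range of 1 nM to 30 nM.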

Compound 4, half-maximal inhibitory concentration: > 7500 nM
Compound 4 ended at the assay's limit (the forecaster's own chance of this, stated with the estimate: 0%); middle value at least 1500-fold (3.17 log units) away from the limit.
By their numbers in this assay, from the lowest: compounds 3 and 1 (each within the scatter of the next); then compound 2. At a limit, above all of these: compound 4.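

Compound 4 gives > 7500 nM in this assay, which is a limit and not a number: the limit of > 7500 nM in this assay, at which 1 of the 4 values shown sits. Even so, the step can be read as a minimum, an at least 3500-fold higher number from compound 1 to compound 4 (3.55 log units; beyond the scatter), and it shows that the chain on this aromatic carbon can decide whether inhibition is seen at all. The earlier steps shown here changed only the other group on the core, whereas here butylcarbonyl, a group of much the same size, fails to stand in for the sulfinyl chain.

Compound 4 changes both the sulfinyl link and the chain length at once, so the compounds shown cannot tell which of the two matters, nor why. A propylcarbonyl group, which keeps the chain length of compound 1, or a butylsulfinyl group, which keeps its sulfinyl link, would pull the two apart.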